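This account rests on a few compounds, and the source may have more. Where it says the series, first, only, none or still open, it means among the compounds named here.

Measured so far:

- Compound 1 `CCNC(=O)Nc1ccc(-c2nc(CS(C)(=O)=O)cc([C@]34CCOC[C@H]3C4)n2)cc1` gives 3.6 in a physicochemical assay for lipophilicity; on this read-out higher numbers stand for higher lipophilicity and lower numbers for lower lipophilicity
- Compound 2 `CCNC(=O)Nc1ccc(-c2nccc([C@]34CCOC[C@H]3C4)n2)cc1` gives 3.9 in this assay

With only these two numbers, compound 2 at 3.9 stands within the scatter of compound 1 and cannot be told apart from it. The next structure is compound 3 `CCNC(=O)Nc1ccc(-c2nccc([C@@]34CCOC[C@@H]3C4)n2)cc1`, and its difference from compound 2 is simple to state (the two compounds have the same atoms and bonds and differ only in configuration as drawn: 2 of 2 stereo elements differ (all stereocentres are inverted: mirror images); a stereocentre at a saturated ring carbon is drawn R in compound 2 and S in compound 3; a stereocentre at a saturated ring carbon is drawn S in compound 2 and R in compound 3). Nothing is added or removed, so the pair are mirror images.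

Among the compounds with values here, the one measured step (a number 0.30 log units higher from compound 1 to compound 2 (within the scatter)) exchanges a group, hydrogen in place of (methylsulfonyl)methyl on an aromatic carbon. Within the data shown here, it therefore says nothing direct about inverting stereocentres, and no measured pair here tests such a change. Since mirror images share every atom and bond, no step beyond the scatter is expected in this assay in either direction. The estimated step (no change at the digits printed from compound 2 to compound 3 (within the scatter)) is accordingly expected to be negligible. Compound 3 is estimated at 3.9 with an expected range of 3.6 to 4.2 around that middle.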

Compound 3, partition coefficient: 3.9
Compound 3: middle estimate and measured number agree at the digits printed; the measured number falls inside the stated range.
By their numbers in this assay, from the lowest: compounds 1, 2 and 3 (each within the scatter of the next).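

In this assay, inverting both stereocentres at the saturated ring carbons gives no change at the digits printed from compound 2 to compound 3 (within the scatter). Within the data shown here, this is the first measured pair to test the configuration of these ring carbons rather than an exchange of groups, with hydrogen on the aromatic carbon in both compounds, so the drawn configuration at this position can be set aside when reading this lipophilicity scale for this pair. The two numbers can be read as the same value, because the structures hold nothing else that could separate them: the fact that compounds 2 and 3 differ only in the configuration as drawn

The compounds shown leave open whether the two mirror-image forms also match in any measurement made against a biological target, since a lipophilicity read-out alone cannot answer that, and whether one form would then stand apart from the other. They also leave open how the number would move with an amine or a carboxylic acid on the aromatic carbon that carries hydrogen in compound 2 and (methylsulfonyl)methyl in compound 1.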